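The source may hold more compounds than are shown below. What is called first, only, known or untested is meant among the compounds shown, and "the series" means these compounds.

Measured in a functional assay on A-431 cells (Homo sapiens) for antiproliferative activity, read by MTT assay, with a stated time of 24 h; on this read-out lower numbers stand for stronger inhibition and higher numbers for weaker inhibition:
- compound 1 `NS(=O)(=O)c1cc2cc(Cl)ccc2oc1=O`: 51900 nM
- compound 2 `NS(=O)(=O)c1cc2cc(Br)ccc2oc1=O`: 38400 nM

Among the compounds with values here, compound 1 has no separate rank, since its only neighbour, compound 2, lies within the scatter of it. Compound 3 `NS(=O)(=O)c1cc2cc(Cl)cc(Cl)c2oc1=O` differs from compound 1 by chloro in place of hydrogen on an aromatic carbon. Within the data shown here, the one measured step, a 1.4-fold lower number from compound 1 to compound 2 (0.13 log units; within the scatter), bears on this only loosely, as it exchanges chloro for bromo and adds no group. No change beyond the scatter is therefore expected in this assay. The estimated step is a 1.2-fold lower number from compound 1 to compound 3 (0.09 log units; within the scatter). Compound 3 is expected at 42000 nM, with an estimated range of 16000 nM to 95000 nM.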

Compound 3, half-maximal inhibitory concentration: 26900 nM
Beside the measured number, compound 3's estimate is 1.6-fold (0.19 log units) above it; the range from low to high includes it.
By their numbers in this assay, from the lowest: compounds 3, 2 and 1 (each within the scatter of the next).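

In this assay, adding chloro in place of hydrogen on the aromatic carbon ortho to a fused ring gives a 1.9-fold lower number from compound 1 to compound 3 (0.29 log units; within the scatter). This position therefore takes a chloro group with no change beyond the scatter, whereas the earlier pair only exchanged chloro for bromo and left this carbon untouched. No supporting data bear on this reading. Going by these compounds, whether a larger group or a different type of group at this carbon, such as an amine or a methoxy group, would shift the number remains open. So does the effect of replacing the sulfonamide with a carboxylic acid.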